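The compounds below may be only part of what the source reports. "The series", "measured", "known", "first", "only" and "open" are said of these compounds alone.

In a functional assay on CCRF-CEM cells (Homo sapiens) for cytotoxicity, read by sulforhodamine B assay, with a stated time of 72 h (a higher number here means a weaker inhibitor, a lower number a stronger inhibitor), compound 3 `OCC#CCSc1cnc2ccccc2c1SCC#CCO` gives 2.6 ug/mL. Among the three compounds measured so far it holds the second highest number: compound 1 `OCC#CCSc1cnc2ccccc2c1Cl` gives 4.1 ug/mL, and the step of a 1.6-fold lower number from compound 1 to compound 3 (0.20 log units; within the scatter) is within the scatter, while compound 2 `OCC#CCSc1cnc2ccccc2c1SCC#CCBr` gives 0.6 ug/mL and the step of a 4.3-fold higher number from compound 2 to compound 3 (0.64 log units; beyond the scatter) is beyond it.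

Compound 4 `COc1c(SCC#CCO)cnc2ccccc12` differs from compound 3 in one place: a group of 2 heavy atoms (1 carbon, 1 oxygen; no ring) in place of a group of 6 heavy atoms (4 carbon, 1 oxygen, 1 sulfur; no ring), on an aromatic carbon.

Among the measured compounds shown here, two measured steps touch this position of the shared core. The step of a 6.8-fold lower number from compound 1 to compound 2 (0.83 log units; beyond the scatter) shows a modest gain when the chlorine there is exchanged for the bromine-bearing chain, whereas the step of a 1.6-fold lower number from compound 1 to compound 3 (0.20 log units; within the scatter) shows that the hydroxyl-bearing chain leaves the number essentially where chlorine had it. For the measured compounds named here, no measured compound carries methoxy at this position, so the effect of that group is unknown here. Since a large change at this site once brought almost nothing, a small group is expected to bring little as well, and the step of a 1.3-fold higher number from compound 3 to compound 4 (0.13 log units; within the scatter) is expected to stay within or near the scatter, leaning toward a slightly higher number. Compound 4 is therefore estimated to give 3.5 ug/mL, with a range from 1.3 ug/mL to 9 ug/mL.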

Compound 4, concentration for 50% inhibition: 22 ug/mL
Beside the measured number, compound 4's estimate is 6.3-fold (0.80 log units) below it; the whole stated range lies below it.
By their numbers in this assay, from the lowest: compound 2; then compounds 3 and 1 (each within the scatter of the next); then compound 4.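

In this assay this position is not indifferent to what it carries: the step of an 8.5-fold higher number from compound 3 to compound 4 (0.93 log units; beyond the scatter) comes with methoxy replacing the hydroxyl-bearing chain, so the near absence of change when that chain replaced chlorine does not hold for every group placed here. Methoxy also compares poorly with the small chloro group, as the step of a 5.4-fold higher number from compound 1 to compound 4 (0.73 log units; beyond the scatter) shows, and the gap is widest against the bromine-bearing chain, with the step of a 37-fold higher number from compound 2 to compound 4 (1.56 log units; beyond the scatter) the largest of the set, which leaves compound 4 with the highest number of the four, beyond the scatter from each of the others. The data offer no measured explanation for why methoxy behaves this way.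

As far as these compounds go, with only chloro, methoxy and two chains seen at this position, it remains open whether small groups in general give a higher number here or whether the result is specific to methoxy, which an amine or a plain methyl would help to settle. From the compounds shown here alone, it is also open whether the low number of compound 2 depends on the bromine itself, which a chain ending in chlorine or an amine, or a longer chain, could test.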